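Anilino variation on the shared core: toward compound 3

The source may hold more compounds than are shown below. What is called first, only, known or untested is meant among the compounds shown, and "the series" means these compounds.

Measured so far:
compound 1 `C#Cc1cccc(Nc2ncnc3ccc(NC(=S)Nc4ccc(S(N)(=O)=O)cc4)cc23)c1` — 13400 nM
compound 2 `NS(=O)(=O)c1ccc(NC(=S)Nc2ccc3ncnc(Nc4ccc(Cl)c(C(F)(F)F)c4)c3c2)cc1` — 11800 nM

In a functional assay on NCI-H1975 cells (Homo sapiens) for antiproliferative activity, read by MTT assay, with a stated time of 72 h (on this read-out lower numbers stand for stronger inhibition and higher numbers for weaker inhibition), compound 1 gives 13400 nM and compound 2 gives 11800 nM. The two numbers lie within the scatter of each other; the step is a 1.1-fold lower number from compound 1 to compound 2 (0.06 log units; within the scatter). Compound 3 `NS(=O)(=O)c1ccc(NC(=S)Nc2ccc3ncnc(Nc4ccc(C(F)(F)F)cc4)c3c2)cc1` carries 4-(trifluoromethyl)phenyl in place of 4-chloro-3-(trifluoromethyl)phenyl on a nitrogen on an aromatic ring. Within the data shown here, the only measured step at this position is a 1.1-fold lower number from compound 1 to compound 2 (0.06 log units; within the scatter), and it stayed within the scatter. By that one step alone, the change is expected to give no step beyond the scatter, i.e. a 1.0-fold higher number from compound 2 to compound 3 (0.01 log units; within the scatter). Compound 3 is therefore estimated at 12000 nM in this assay, with a range from 5000 nM to 30000 nM.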

Compound 3, half-maximal inhibitory concentration: 17100 nM
The estimate for compound 3 lay 1.4-fold (0.15 log units) below the measured number, within the range that was stated.
By their numbers in this assay, from the lowest: compounds 2, 1 and 3 (each within the scatter of the next).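

In this assay, 4-(trifluoromethyl)phenyl in place of 4-chloro-3-(trifluoromethyl)phenyl gives a 1.4-fold higher number from compound 2 to compound 3 (0.16 log units; within the scatter), and in place of 3-ethynylphenyl it gives a 1.3-fold higher number from compound 1 to compound 3 (0.11 log units; within the scatter). All three groups on this nitrogen now lie within the scatter of one another, so taking away the chlorine leaves no readable change, and the position stays flat across compound 1, compound 2 and compound 3. From the compounds shown here alone, whether an amine, a carboxylic acid or a longer chain on this ring would move the number beyond the scatter remains open. No evidence at hand bears on why these three groups read alike.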